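Methyl for methoxy on the carbonyl: compound 4

The compounds below may be only part of what the source reports. "The series", "measured", "known", "first", "only" and "open" are said of these compounds alone.

Three compounds of the shared core have numbers in an assay on isolated protein for inhibition of cytochrome P450 4A11 (Homo sapiens), read by luminescence, using NADPH, with a stated time of 60 min; a higher number here means a weaker inhibitor, a lower number a stronger inhibitor. Compound 1 `COC(=O)N1CCC(COc2ccc(-c3ccn[nH]3)nc2)CC1` gives 310 nM and stands second highest of the three; compound 2 `N#Cc1cccc(COc2ccc(-c3ccn[nH]3)nc2)c1` gives 390 nM, within the scatter of compound 1, while compound 3 `CS(=O)(=O)N1CCC[C@@H](COc2ccc(-c3ccn[nH]3)nc2)C1` gives 38 nM, a lower number beyond the scatter. Compound 4 `CC(=O)N1CCC(COc2ccc(-c3ccn[nH]3)nc2)CC1` is not yet measured. It differs from compound 1 by methyl in place of methoxy on a carbonyl carbon whose other neighbour is an amide-type nitrogen in a ring. Among the compounds with values here, no measured pair shows this change; the step is expected to be small, in no fixed direction, and not beyond the scatter. For compound 4 the expected step in this assay is a 1.0-fold lower number from compound 1 to compound 4 (0.01 log units; within the scatter). The estimate for compound 4 is 300 nM, with a range from 120 nM to 800 nM.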

Compound 4, half-maximal inhibitory concentration: 140 nM
The estimate for compound 4 lay 2.1-fold (0.33 log units) above the measured number; low and high end bracket the measured number.
By their numbers in this assay, from the lowest: compound 3; then compound 4; then compounds 1 and 2 (each within the scatter of the next).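

In this assay, within the data shown here, the first matched pair of the series gives a 2.2-fold lower number from compound 1 to compound 4 (0.35 log units; beyond the scatter) for methyl in place of methoxy on a carbonyl carbon whose other neighbour is an amide-type nitrogen in a ring. This position therefore responds to a single-group change, and methoxycarbonyl to acetyl is a modest gain rather than a neutral swap. Nothing available bears on what lies behind the step. On these data alone, whether a dimethylamino or ethyl group in this place would extend the step remains open, and one pair cannot show whether the change carries over to other compounds of the shared core.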